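The source may report more compounds than this note shows. Statements on the series, on what has been measured and on what is new or still open speak of the compounds shown alone.

Measured compounds in a functional assay on SMMC-7721 cells (Homo sapiens) for inhibition, read by CCK-8 assay, with a stated time of 72 h, tested at 8 uM; on this read-out higher numbers stand for more inhibition of growth at the one concentration tested and lower numbers for less inhibition of growth:
compound 1 `Cc1ccc(SCc2ccc(/C=C/C(=O)Nc3ccccc3N)cc2)cc1` gives 22.2%;
compound 2 `Nc1ccccc1NC(=O)c1ccc(CSc2nccc(C(F)(F)F)n2)cc1` gives 80.6%;
compound 3 `CC(C)(C)c1ccc(SCc2ccc(C(=O)Nc3ccccc3N)cc2)cc1` gives 46.1%.

Compound 1 stands lowest of these three numbers. Compound 3 is nearest to it, lying above it by more than the scatter, and compound 2 lies furthest above, also beyond the scatter. The step from compound 1 to compound 4 `Nc1ccccc1NC(=O)/C=C/c1ccc(CSc2ccc(C(F)(F)F)cn2)cc1` is 5-(trifluoromethyl)pyridin-2-yl in place of 4-methylphenyl on a sulfur. Among the measured compounds shown here, no measured pair shows this change on its own. Compound 2 also carries a trifluoromethyl group on the group joined to the sulfur and gives the highest number, but it differs from compound 1 in more than one place, so the size of the step remains uncertain. An upward step beyond the scatter, a number 32.8 percentage points higher from compound 1 to compound 4 (beyond the scatter), is expected. Compound 4 is estimated at 55% in this assay, with a range from 30% to 80%.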

Compound 4, percent growth inhibition at one concentration: 20.1%
Compound 4: middle estimate off by 34.9 percentage points, on the high side; measured number below the stated range.
By their numbers in this assay, from the lowest: compounds 4 and 1 (each within the scatter of the next); then compound 3; then compound 2.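

In this assay, the exchange of 4-methylphenyl for 5-(trifluoromethyl)pyridin-2-yl on a sulfur gives a number 2.1 percentage points lower from compound 1 to compound 4 (within the scatter), so this read-out does not separate the two groups. At this position, a ring with one hetero atom and a trifluoromethyl group therefore gives a number within the scatter of the 4-methylphenyl ring. Nothing available explains this result. Going by these compounds, it remains open whether an amine, a carboxylic acid or a longer chain in place of 4-methylphenyl on a sulfur would give a step beyond the scatter.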